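Swapping Bromine for Iodine on the Benzyl Group

The compounds below may be only part of what the source reports. "The series", "measured", "known", "first", "only" and "open" are said of these compounds alone.

Compound 1 `CCCCC#Cc1nc(NCc2cccc(Br)c2)c2ncn([C@@H]3OC[C@@H](O)[C@H]3O)c2n1` carries a 3-bromobenzyl group on its core. Among the measured compounds shown here, in an assay on CHO cells for displacement of a labelled ligand from adenosine receptor A3 (Homo sapiens), with a stated time of 60 min (on this read-out lower numbers stand for stronger inhibition and higher numbers for weaker inhibition), compound 1 gives 67 nM, the higher of the two numbers measured so far. For the measured compounds named here, its only measured neighbour is compound 2 `CCCCC#Cc1nc(NCc2cccc(Br)c2)c2ncn([C@@H]3SC[C@@H](O)[C@H]3O)c2n1`, which in this assay gives 24 nM; that step, a 2.8-fold lower number from compound 1 to compound 2 (0.45 log units; beyond the scatter), alters the ring on the aromatic nitrogen and says nothing about the benzyl group. Compound 3 `CCCCC#Cc1nc(NCc2cccc(I)c2)c2ncn([C@@H]3OC[C@@H](O)[C@H]3O)c2n1` differs from compound 1 only there: iodo in place of bromo on an aromatic carbon. Going by the values given here, no measured step touches this position, so the expectation rests on the halogen swap alone, and neighbouring halogens of this kind commonly give numbers close to one another. Compound 3 is therefore expected to stay near compound 1, with an expected step of a 1.2-fold lower number from compound 1 to compound 3 (0.09 log units; within the scatter) that lies within the scatter. The estimate for compound 3 in this assay is 55 nM, within a range from 20 nM to 160 nM.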

Compound 3, inhibition constant: 220 nM
Compound 3: middle estimate off by 4.0-fold (0.60 log units), on the low side; the measured number lies above the stated range.
By their numbers in this assay, from the lowest: compound 2; then compound 1; then compound 3.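

The halogen on the benzyl group matters: going from 3-bromobenzyl to 3-iodobenzyl gives a 3.3-fold higher number from compound 1 to compound 3 (0.52 log units; beyond the scatter) in this assay even though one halogen atom simply replaces another and no hydrogen-bond donor or acceptor is gained or lost. Among the compounds shown here, this is the first measured step at this position, as the earlier step changed only the ring on the aromatic nitrogen, and of the two halogens compared here on this core, bromo gives the lower number. Nothing available explains why the number rises with iodo.

The compounds shown leave open whether chloro, fluoro or methoxy on the same aromatic carbon would give a lower or higher number than bromo. They also leave open whether swapping bromo for iodo would give a similar step on compound 2, which carries the sulfur-containing ring.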